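The source may report more compounds than this note shows. Statements on the series, on what has been measured and on what is new or still open speak of the compounds shown alone.

Compound 1 `CCSc1nnc(COc2ccccc2C2=NOC(c3ccc(Cl)cc3Cl)C2)n1NC(=O)c1ccccc1`, which bears an ethylsulfanyl group and a phenyl on a carbonyl carbon on the shared core, gives 1.8 ug/mL in an ADME assay (MDM cells, Homo sapiens) for cytotoxicity, read by resazurin assay, with a stated time of 3 days (on this read-out lower numbers stand for stronger inhibition and higher numbers for weaker inhibition), the lowest of the two numbers available. Compound 3 `CCSc1nnc(COc2ccccc2C2=NOC(c3ccc(Cl)cc3Cl)C2)n1NC(C)=O` differs from compound 1 by methyl in place of phenyl on a carbonyl carbon; in this assay compound 3 gives 9.7 ug/mL. The step of a 5.4-fold higher number from compound 1 to compound 3 (0.73 log units; beyond the scatter) is modest but beyond the scatter. In this assay compound 2 `CCOC(=O)CC(=O)CSc1nnc(COc2ccccc2C2=NOC(c3ccc(Cl)cc3Cl)C2)n1NC(C)=O` gives "not determined" (no result reported), so no result for it was reported.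

Compound 4 `CSc1nnc(COc2ccccc2C2=NOC(c3ccc(Cl)cc3Cl)C2)n1NC(=O)c1ccccc1` differs from compound 1 by hydrogen in place of methyl on a saturated chain carbon bound to a sulfur. Read one bond further out, the ethylsulfanyl of compound 1 becomes methylsulfanyl in compound 4. Within the data shown here, no measured step touches this chain: the one step available, from compound 1 to compound 3, changes only the group on the carbonyl carbon. Shortening the sulfur-bound chain by one carbon is therefore judged, with little support, to give no step beyond the scatter in this assay. Compound 4 is expected to show 2.2 ug/mL, between 0.9 ug/mL and 5.5 ug/mL, which means an expected step of a 1.2-fold higher number from compound 1 to compound 4 (0.09 log units; within the scatter) that stays within the scatter.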

Compound 4, half-maximal inhibitory concentration: 2.2 ug/mL
The estimate for compound 4 equals the measured number at the digits printed, and the stated range covers the measured number.
By their numbers in this assay, from the lowest: compounds 1 and 4 (each within the scatter of the next); then compound 3.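

In this assay, among these compounds, the sulfur-bound chain can now be read for the first time: ethylsulfanyl to methylsulfanyl, with the phenyl on the carbonyl carbon kept, gives a 1.2-fold higher number from compound 1 to compound 4 (0.09 log units; within the scatter) and so no step beyond the scatter. The only earlier step, a 5.4-fold higher number from compound 1 to compound 3 (0.73 log units; beyond the scatter), lay at the carbonyl carbon and went beyond the scatter, so among these three compounds only that place shows a step of that kind. Nothing measured here offers a reason for either result.

Going by these compounds, what a propyl chain on the sulfur, or a carboxylic acid at the end of that chain, would give in this assay stays open. So does whether ethylsulfanyl to methylsulfanyl would read the same with methyl on the carbonyl carbon, as in compound 3.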